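Cell tolerance across a small series of related compounds

The source may report more compounds than this note shows. Statements on the series, on what has been measured and on what is new or still open speak of the compounds shown alone.

Measured in a functional assay on Huh-7 cells (Homo sapiens) for cytotoxicity, read by MTT assay, with a stated time of 3 days; a higher number here means that more compound is tolerated, a lower number that less compound is tolerated:
compound 1 `OC[C@H]1O[C@@H](n2cnc3c(CSCc4ccccc4)ncnc32)[C@H](O)[C@@H]1O`, a limit of the assay: > 100000 nM
compound 2 `O=C1CCCN1Cc1ncnc2c1ncn2[C@@H]1O[C@H](CO)[C@@H](O)[C@H]1O`: 45000 nM
compound 3 `OC[C@H]1O[C@@H](n2cnc3c(Cn4cccn4)ncnc32)[C@H](O)[C@@H]1O`, a limit of the assay: > 250000 nM

Compound 1 stands only at a limit in this assay, (the limit of > 100000 nM in this assay, at which 1 of the 3 values shown sits). Compound 3 likewise sits at a limit, (the limit of > 250000 nM in this assay, at which 1 of the 3 values shown sits). Compound 4 `COCc1ncnc2c1ncn2[C@@H]1O[C@H](CO)[C@@H](O)[C@H]1O` differs from compound 1 by methoxy in place of benzylsulfanyl on a saturated chain carbon bound to an aromatic carbon.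

Among the compounds with values here, the steps that bear on this change exchange the same benzylsulfanyl group: an at least 2.2-fold lower number from compound 1 to compound 2 (0.34 log units; beyond the scatter), while a step that the two limits leave unreadable from compound 1 to compound 3, and an at least 5.5-fold higher number from compound 2 to compound 3 (0.74 log units; beyond the scatter). A small group entering at the same place thus gave either a lower number or a value left at a limit.

Compound 4 is expected to give 120000 nM, with a range of 40000 nM to 300000 nM. The expected step is therefore a step that the limit leaves unreadable from compound 1 to compound 4, not clearly beyond the scatter, with a fair chance that only a limit is reported again.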

Compound 4, half-maximal cytotoxic concentration: > 100000 nM
Compound 4 gave a limit, no number (the forecaster's own chance of this, stated with the estimate: 55%); the middle value does not contradict the limit.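

In this assay compound 4 also stands at a limit, so methoxy in place of benzylsulfanyl removes the aromatic ring without yielding a measured number: the limit of > 100000 nM in this assay, at which 2 of the 4 values shown sit.

Methoxy in place of 2-oxopyrrolidin-1-yl gives an at least 2.2-fold higher number from compound 2 to compound 4 (0.34 log units; beyond the scatter), leaving 2-oxopyrrolidin-1-yl as the only one of the four groups at this place with a measured number. The steps among compound 1, compound 3 and compound 4 cannot be read.

On these data alone, how far these three compounds differ therefore remains open. Also open, as far as these compounds go, is whether an amine or a carboxylic acid at this place would give a measured number, as 2-oxopyrrolidin-1-yl does.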